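A Ring Exchange on the Methylated Compound

The source may report more compounds than this note shows. Statements on the series, on what has been measured and on what is new or still open speak of the compounds shown alone.

In a functional assay on PC-3 cells (Homo sapiens) for inhibition, read by sulforhodamine B assay (a higher number here means a weaker inhibitor of growth, a lower number a stronger inhibitor of growth), compound 1 `Cc1ccc2[nH]c(-c3ccc(-c4ccc(-c5cccc(Cl)c5)cc4)cc3)nc2c1` gives 2670 nM and stands lowest of the three measured compounds. Compound 3 `Clc1cccc(-c2ccc(-c3ccc(-c4nc5ccccc5[nH]4)cc3)cc2)c1` gives 33700 nM and compound 2 `FC(F)(F)c1ccc(-c2ccc(-c3ccc(-c4nc5ccccc5[nH]4)cc3)cc2)cc1` gives 45200 nM in the same test, and both lie beyond the scatter from compound 1.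

Compound 4 `Cc1ccc2[nH]c(-c3ccc(-c4ccc(-c5ccc(OC(F)(F)F)cc5)cc4)cc3)nc2c1` has not yet been measured. It carries 4-(trifluoromethoxy)phenyl in place of 3-chlorophenyl on an aromatic carbon and keeps the methyl of compound 1.

Within the data shown here, two measured steps bear on this change. The nearer one, 3-chlorophenyl in place of 4-(trifluoromethyl)phenyl, gives a 1.3-fold lower number from compound 2 to compound 3 (0.13 log units; within the scatter) and so shows an exchange of this kind without a measurable effect. Among the measured compounds shown here, it is only a guide, since no measured compound carries the group that enters compound 4. The other, hydrogen in place of methyl on an aromatic carbon, gives a 13-fold higher number from compound 1 to compound 3 (1.10 log units; beyond the scatter) and is large, but compound 4 keeps that methyl, so this loss does not apply.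

No step beyond the scatter is therefore expected in this assay and the estimated change is a 1.1-fold higher number from compound 1 to compound 4 (0.05 log units; within the scatter) for this exchange. Compound 4 is estimated to give 3000 nM with an expected range from 1000 nM to 9000 nM once it is measured.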

Compound 4, concentration for 50% growth inhibition: 2010 nM
The estimate for compound 4 lay 1.5-fold (0.17 log units) above the measured number; low and high end bracket the measured number.
By their numbers in this assay, from the lowest: compounds 4 and 1 (each within the scatter of the next); then compounds 3 and 2 (each within the scatter of the next).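

On the methylated core, the exchange of 3-chlorophenyl for 4-(trifluoromethoxy)phenyl in this assay gives a 1.3-fold lower number from compound 1 to compound 4 (0.12 log units; within the scatter), so this aromatic carbon accepts a change of aryl group with the methyl in place, something the earlier exchange could show only on compounds without that methyl. The entering group differs from the leaving one in its substituent and in carrying a hydrogen-bond acceptor where 3-chlorophenyl has none, yet the number stays within the scatter, and the two measured aryl exchanges, one with the methyl and one without it, now agree in leaving the read-out in place. Nothing shown gives a reason for this lack of effect or says what the aryl group contributes to growth inhibition in these cells.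

The compounds shown leave open whether this tolerance extends to an aryl group bearing an amine or a carboxylic acid, since every group seen at this place so far carries a halogen or a fluorinated substituent. They also leave open whether a longer chain, such as ethyl or propyl, in place of the methyl would hold or extend the gain seen with the methyl.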